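Propylcarbamoyl in place of thiophene carbonyl on the shared core

The compounds below may be only part of what the source reports. "The series", "measured", "known", "first", "only" and "open" are said of these compounds alone.

Measured compounds:
compound 1 `CN1CCC(C(=O)N2Cc3c(NC(=O)c4ccsc4)n[nH]c3C2(C)C)CC1`: 140 nM in a functional assay on A2780 cells (Homo sapiens) for antiproliferative activity, read by fluorescence, with a stated time of 72 h; a lower number here means a stronger inhibitor, a higher number a weaker inhibitor
compound 2 `CC(=O)N1CCC(C(=O)N2Cc3c(NC(=O)c4ccc(F)cc4)n[nH]c3C2(C)C)CC1`: > 10000 nM in this assay, which is a limit of the assay and not a number
compound 3 `CCN1CCC(C(=O)N2Cc3c(NC(=O)c4ccc(F)cc4)n[nH]c3C2(C)C)CC1`: 290 nM in this assay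

Among the numbers shown, compound 1 has the lower number and compound 3 the higher. Compound 2 sits at the limit of > 10000 nM in this assay, at which 1 of the 3 values shown sits, and gives no number. For the measured compounds named here, the one step measured in one place, an at least 34-fold lower number from compound 2 to compound 3 (1.53 log units; beyond the scatter), concerns the amine nitrogen in a ring and leaves the acyl group on the amide-type nitrogen untouched.

Compound 4 `CCCNC(=O)Nc1n[nH]c2c1CN(C(=O)C1CCN(C)CC1)C2(C)C` keeps the methylated ring amine of compound 1 and differs from it only at that acyl group: propylamino in place of thiophen-3-yl on a carbonyl carbon. No measured step bears on the exchange of (thiophen-3-yl)carbonyl for propylcarbamoyl, so the direction rests on no shown evidence; a step towards a weaker inhibitor is taken as the working expectation, with wide uncertainty. Compound 4 is therefore expected at 450 nM, between 80 nM and 3000 nM. The expected step is a 3.2-fold higher number from compound 1 to compound 4 (0.51 log units; beyond the scatter).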

Compound 4, half-maximal inhibitory concentration: 650 nM
Beside the measured number, compound 4's estimate is 1.4-fold (0.16 log units) below it; low and high end bracket the measured number.
By their numbers in this assay, from the lowest: compound 1; then compound 3; then compound 4. At a limit, above all of these: compound 2.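

The acyl group on the amide-type nitrogen now has its first measured step: propylamino in place of thiophen-3-yl on a carbonyl carbon gives a 4.6-fold higher number from compound 1 to compound 4 (0.67 log units; beyond the scatter) in this assay. The step is modest and runs towards a weaker inhibitor, yet compound 4, with no ring in this group, still gives a number, 650 nM, and not a limit of the assay. Nothing shown gives a cause for this step.

Still open, going by these compounds, is whether the step belongs to the loss of the thiophen-3-yl ring or to the entry of the nitrogen of propylamino, as the two change together here. A plain butyl chain or a benzylamino group on the same carbonyl carbon would help to separate the two.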